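The compounds below may be only part of what the source reports. "The series", "measured", "known", "first", "only" and "open" are said of these compounds alone.

Measured so far in a functional assay on the whole organism (Tail, strain ICR) with Mus musculus as the target, in the tail flick test, with a stated time of 150 min, at a dose of 25 umol/kg by the oral route; a lower number here means a weaker effect, a higher number a stronger effect of the compound at the dose given:
- compound 1 `CC[C@H](C)[C@H](NC(=O)CN(c1nc(Cl)nc2[nH]cnc12)C1CC1)C(=O)O`: 6.71%
- compound 2 `C[C@@H](O)[C@H](NC(=O)CN(c1nc(Cl)nc2[nH]cnc12)C1CC1)C(=O)O`: 24%
- compound 3 `CC(C)[C@H](NC(=O)CN(c1nc(Cl)nc2[nH]cnc12)C1CC1)C(=O)O`: 7.86%

Compound 3 stands second highest of the three numbers in this assay; its nearest neighbour is compound 1, with a number 1.2 percentage points higher from compound 1 to compound 3 (within the scatter), a gap within the scatter, so the two cannot be ordered. Its furthest neighbour is compound 2, with a number 16.1 percentage points lower from compound 2 to compound 3 (beyond the scatter).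

Compound 4 `O=C(O)C[C@H](NC(=O)CN(c1nc(Cl)nc2[nH]cnc12)C1CC1)C(=O)O` is the next compound, not yet measured. The change from compound 3 is carboxymethyl in place of isopropyl on a saturated chain carbon bound to an amide-type nitrogen and a carbonyl carbon.

Going by the values given here, two measured steps bear on this. a number 17.3 percentage points higher from compound 1 to compound 2 (beyond the scatter) and a number 16.1 percentage points lower from compound 2 to compound 3 (beyond the scatter) both show that the one compound of the three carrying an oxygen-bearing side chain on the saturated chain carbon bound to an amide-type nitrogen and a carbonyl carbon gives the higher number, while the two carrying plain alkyl groups give low numbers close to each other. Among the compounds with values here, compound 4 likewise brings an oxygen-bearing group in at that position, though a carboxymethyl rather than a 1-hydroxyethyl, and no step with a carboxymethyl has been measured. A modest upward step is therefore expected, a number 8.1 percentage points higher from compound 3 to compound 4 (within the scatter), with wide uncertainty. Compound 4 is estimated at 16% in this assay, within a range of 3% to 36%.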

Compound 4, a percentage reported as activity, at one dose (the size of the read-out at that dose, not a potency): 11.6%
The estimate for compound 4 lay 4.4 percentage points above the measured number; the range from low to high includes it.
By their numbers in this assay, from the lowest: compounds 1, 3 and 4 (each within the scatter of the next); then compound 2.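

In this assay, carboxymethyl in place of isopropyl on a saturated chain carbon bound to an amide-type nitrogen and a carbonyl carbon does not set compound 4 apart from the compounds with plain alkyl groups: the result is a number 3.7 percentage points higher from compound 3 to compound 4 (within the scatter) and, against sec-butyl, a number 4.9 percentage points higher from compound 1 to compound 4 (within the scatter) at this position. The step from 1-hydroxyethyl, a number 12.4 percentage points lower from compound 2 to compound 4 (beyond the scatter) in this assay, shows that an oxygen-bearing side chain does not by itself go with the higher number, so compound 4 goes against that reading and compound 2 alone stands apart among the four. No measurement at hand accounts for the difference between the 1-hydroxyethyl and carboxymethyl groups.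

The compounds shown leave open whether the higher number of compound 2 follows the hydroxy group alone or the whole 1-hydroxyethyl group, a question that hydroxymethyl at this position would address. They also leave open whether the carboxylic acid of carboxymethyl matters here, which a primary amide such as carbamoylmethyl or the longer chain of 2-carboxyethyl would test.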